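This account rests on a few compounds, and the source may have more. Where it says the series, first, only, none or still open, it means among the compounds named here.

The three compounds measured in a functional assay on A-375 cells (Homo sapiens) for activation, with a stated time of 3 days (a lower number here means that less compound is needed, a higher number that more compound is needed for the effect), are:

compound 1, `O=C(Nc1ccc(-c2cscn2)cc1)C1CCN(Cc2ccc(F)c(F)c2)CC1`, 19000 nM
compound 2, `O=C(Nc1ccc(-c2cscn2)cc1)C1CCCN(Cc2ccc3cn[nH]c3c2)C1`, > 20000 nM
compound 3, `O=C(Nc1ccc(-c2ccccc2)cc1)C1CCCN(Cc2ccc(F)c(F)c2)C1`, 5000 nM

Of the two numbers, compound 3 carries the lower one in this assay, and its distance to compound 1 is beyond the scatter. For compound 2 the result in this assay is a limit of the assay rather than a number, (the limit of > 20000 nM in this assay, at which 1 of the 3 values shown sits). Going by the values given here, compound 1 and compound 2 both differ from compound 3 in more than one place, so no single step between measured compounds can be drawn from them.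

The account now follows the step from compound 3 to compound 4, `O=C(Nc1ccc(-c2cc[nH]c2)cc1)C1CCCN(Cc2ccc(F)c(F)c2)C1`, which has not yet been measured in this assay. The change is 1H-pyrrol-3-yl in place of phenyl on an aromatic carbon. The phenyl that leaves sits on an aromatic carbon, para to a large group, and 1H-pyrrol-3-yl enters there.

Among the compounds with values here, since no measured pair isolates this change, the expectation rests on the values of compound 3 and compound 1 alone. The estimate is that compound 4 shows a step of a 1.6-fold higher number from compound 3 to compound 4 (0.20 log units; within the scatter), a modest rise that may stay within the scatter. Compound 4 is thus expected to give about 8000 nM in this assay, within a range from 2500 nM to 25000 nM.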

Compound 4, half-maximal effective concentration: 2610 nM
Estimate against measurement, compound 4: 3.1-fold (0.49 log units) above; the measured number falls inside the stated range.
By their numbers in this assay, from the lowest: compounds 4 and 3 (each within the scatter of the next); then compound 1. At a limit, above all of these: compound 2.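

Going by these compounds alone, this is the first step that isolates a single change, the exchange of phenyl for 1H-pyrrol-3-yl, and in this assay it reads a 1.9-fold lower number from compound 3 to compound 4 (0.28 log units; within the scatter). The aromatic carbon para to a large group therefore takes the five-membered ring, with its nitrogen and its hydrogen-bond donor, without a shift that stands clear of the scatter, so the six-membered ring of carbon only is not required there for activity at this level. Nothing measured in the compounds shown bears on what lies behind this step.

The compounds shown leave open whether the hydrogen on the pyrrole nitrogen or the size of the ring counts at this position, and 1-methyl-1H-pyrrol-3-yl or a pyridyl group in the same place would help to separate the two. From the compounds shown here alone, it also remains open whether the change would read the same way with a group other than the one carried elsewhere on the shared core of compound 3 and compound 4.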